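Working notes: a drawn stereocentre in the series

The compounds below may be only part of what the source reports. "The series", "measured", "known", "first", "only" and "open" are said of these compounds alone.

- compound 1 (`NC1CCc2nc(-c3ccncc3)nc(Nc3cccc(F)c3)c2C1`) gives 13900 nM in a functional assay on MCF7 cells (Homo sapiens) for antiproliferative activity, read by MTT assay, with a stated time of 72 h; a lower number here means a stronger inhibitor, a higher number a weaker inhibitor
- compound 2 (`COc1cccc(Nc2nc(-c3ccncc3)nc3c2CC(N)CC3)c1`) gives 15800 nM in this assay

Among the measured compounds shown here, compound 1 sits level with its only measured neighbour (a 1.1-fold higher number from compound 1 to compound 2 (0.06 log units; within the scatter)) on these two numbers. For the measured compounds named here, compound 3 (`N[C@H]1CCc2nc(-c3ccncc3)nc(Nc3cccc(F)c3)c2C1`) has the same atoms and bonds as compound 1 (the two compounds have the same atoms and bonds; at least one stereo element is drawn with a configuration in one of them and without one in the other: 1 of 1 stereo elements differ; a stereocentre at a saturated ring carbon is drawn without a configuration in compound 1 and S in compound 3), and the stereocentre at a saturated ring carbon is drawn as S. The one measured step concerns an aromatic substituent, and no measured step tests the configuration. No step beyond the scatter is therefore expected in this assay, in either direction. For compound 3 the estimated value is 12000 nM (expected range 6000 nM to 25000 nM). The estimated step is small (a 1.2-fold lower number from compound 1 to compound 3 (0.06 log units; within the scatter)).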

Compound 3, half-maximal inhibitory concentration: 14200 nM
Compound 3: middle estimate off by 1.2-fold (0.07 log units), on the low side, and the stated range covers the measured number.
By their numbers in this assay, from the lowest: compounds 1, 3 and 2 (each within the scatter of the next).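

In this assay, among the compounds shown here, the first measured step at the stereocentre at a saturated ring carbon is a 1.0-fold higher number from compound 1 to compound 3 (0.01 log units; within the scatter). The S drawing therefore cannot be separated from the undefined drawing on these numbers. This comparison carries one limit, since the configuration is defined on only one side: the fact that one of compounds 1 and 3 is drawn with a defined configuration and the other without, at the place where they differ

The compounds shown leave open whether the R configuration gives a different number in this assay. They also leave open whether an amide or a hydroxyl group in place of the amine on this ring carbon would do so.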